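A few compounds are considered here, and "the series" means these few. Any claim that something is new, unique, unknown or untested is made for them only; others in the source may bear on it.

Measured compounds:
Compound 1, `CCCn1ccc2cc(N3CCC(O)CC3)cc(Cl)c2c1=O`: in a functional assay on CHO cells for agonist activity at metabotropic glutamate receptor 2 (Homo sapiens), read by GTPgammaS binding (on this read-out higher numbers stand for an effect only at larger amounts of compound and lower numbers for an effect already at smaller amounts), compound 1 gives 5010 nM.
Compound 2, `CCCn1ccc2cc(OCc3cccnc3)cc(Cl)c2c1=O`: in this assay compound 2 gives 2510 nM.

Among the compounds with values here, compound 2 stands at the lowest of the two numbers so far; its nearest neighbour is compound 1, whose number is higher by an amount that lies within the scatter, so no order between the two can be read from these values.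

Compound 3, `CCCn1ccc2cc(OCCCc3cccnc3)cc(Cl)c2c1=O`, is not yet measured in this assay. It differs from compound 2 in one place: 2-(pyridin-3-yl)ethyl in place of pyridin-3-yl on a saturated chain carbon bound to an oxygen on an aromatic ring. Within the data shown here, no step between two measured compounds that differ in one place is available, so this kind of change has no precedent. The pyridin-3-yl ring and the oxygen on the aromatic ring are kept; only the saturated chain grows. Among the measured compounds shown here, with no comparable step to draw on, no movement beyond the scatter is expected in either direction, and a wide range is allowed on both sides.

Compound 3 is expected to give 3000 nM in this assay, with a range from 800 nM to 12000 nM. The expected step, a 1.2-fold higher number from compound 2 to compound 3 (0.08 log units; within the scatter), thus lies within the scatter.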

Compound 3, half-maximal effective concentration: 631 nM
Estimate against measurement, compound 3: 4.8-fold (0.68 log units) above; the whole stated range lies above it.
By their numbers in this assay, from the lowest: compound 3; then compounds 2 and 1 (each within the scatter of the next).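

Within the data shown here, at the saturated chain carbon bound to an oxygen on an aromatic ring, the change from pyridin-3-yl to 2-(pyridin-3-yl)ethyl gives the only step so far that lies beyond the scatter: in this assay, the number falls, a 4.0-fold lower number from compound 2 to compound 3 (0.60 log units; beyond the scatter). This position therefore accepts the larger group with the pyridin-3-yl ring and the oxygen on the aromatic ring kept, and the modest shift runs towards effect at smaller amounts of compound, which the two earlier values, lying within the scatter of each other, could not show. No measurement is available that accounts for this step.

Still open, from the compounds shown here alone, is whether the number keeps falling with a longer chain such as 3-(pyridin-3-yl)propyl, or whether the step is already at its limit with 2-(pyridin-3-yl)ethyl. A single step also leaves open whether the pyridin-3-yl ring is needed at the end of the chain, or whether a phenyl ring or an amine there would give a similar number.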